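The source may report more compounds than this note shows. Statements on the series, on what has been measured and on what is new or still open speak of the compounds shown alone.

Measured in a functional assay, read by spectrophotometry, with a stated time of 30 min (on this read-out lower numbers stand for stronger inhibition and higher numbers for weaker inhibition), the three compounds read as follows

Compound 1 `O=C(/C=C/c1ccccc1)NCCC1CCN(Cc2ccccc2)CC1` gives > 200000 nM
Compound 2 `CC(C)(C)c1cc(CCC(=O)NC2CCN(Cc3ccccc3)CC2)cc(C(C)(C)C)c1O` gives 80300 nM
Compound 3 `COc1ccc(CN2CCC(CCNC(=O)/C=C/c3cc(C(C)(C)C)c(O)c(C(C)(C)C)c3)CC2)cc1` gives 61200 nM

The entry for compound 1 (> 200000 nM) is a limit of the assay and not a number. Compound 3 (61200 nM) sits with compound 2 (80300 nM) within the usual scatter of repeated measurements, so these two numbers cannot be ranked.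

Compound 4 (`CC(C)(C)c1cc(/C=C/C(=O)NCCC2CCN(Cc3ccccc3F)CC2)cc(C(C)(C)C)c1O`) has not yet been measured. It differs from compound 3 at one place: 2-fluorophenyl in place of 4-methoxyphenyl, on a saturated chain carbon bound to an amine nitrogen in a ring (2-fluorophenyl in place of 4-methoxyphenyl on a saturated chain carbon bound to an amine nitrogen in a ring). Cut one bond further out, the same difference reads 4-methoxybenzyl to 2-fluorobenzyl.

Within the data shown here, no two measured compounds differ in one place only, so the data give neither a size nor a direction for this swap. The expectation in this assay is therefore no step beyond the scatter, with compound 3 (61200 nM) as the starting point. The estimated step (a 1.2-fold lower number from compound 3 to compound 4 (0.09 log units; within the scatter)) is small, but the range stays wide, as a single close neighbour is a thin base for any forecast. For compound 4 the estimate is 50000 nM (expected range 12000 nM to 180000 nM).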

Compound 4, half-maximal inhibitory concentration: 55900 nM
For compound 4 the middle estimate is 1.1-fold (0.05 log units) below the measured one; the range from low to high includes it.
By their numbers in this assay, from the lowest: compounds 4, 3 and 2 (each within the scatter of the next). At a limit, above all of these: compound 1.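

Among these compounds, the first pair of compounds that differ in one place only gives, in this assay, a 1.1-fold lower number from compound 3 to compound 4 (0.04 log units; within the scatter). On a saturated chain carbon bound to an amine nitrogen in a ring, 2-fluorophenyl can therefore stand in place of 4-methoxyphenyl without a difference this read-out can resolve, even though the entering group has one heavy atom fewer and no hydrogen-bond acceptor, where the leaving group has one. The two numbers cannot be ranked, and no measured property at hand bears on why they read alike.

This single swap alters both the ring substituent and its stated ring position, so its two parts stay unseparated; 4-fluorophenyl and 2-methoxyphenyl would each carry only one of them. Going by these compounds, it also remains open whether this position tolerates groups of a different kind, such as a plain phenyl or a phenyl carrying a carboxylic acid or an amine, since both groups compared here are substituted phenyl rings with no net charge.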